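The compounds below may be only part of what the source reports. "The series", "measured", "known", "first", "only" and "open" are said of these compounds alone.

Compound 1 `CC(C)(C)C1=CC(=O)C=CC1=O` gives 95000 nM
Compound 2 `CCNC1=CC(=O)C(C(C)(C)C)=CC1=O` gives 75000 nM

In an ADME assay on HaCaT cells (Homo sapiens) for cytotoxicity, read by MTT assay, with a stated time of 72 h (a lower number here means a stronger inhibitor, a higher number a weaker inhibitor), compound 2 stands at 75000 nM and cannot be separated from compound 1. Compound 3 `CC(C)(C)C1=CC(=O)C(NCc2ccccc2)=CC1=O` has phenyl in place of methyl on a saturated chain carbon bound to an amine nitrogen. Among the measured compounds shown here, the only measured step is a 1.3-fold lower number from compound 1 to compound 2 (0.10 log units; within the scatter) and it concerns a different change, ethylamino in place of hydrogen on a double-bonded ring carbon. It offers weak guidance, and no step beyond the scatter is expected. The estimate means a 1.3-fold lower number from compound 2 to compound 3 (0.10 log units; within the scatter) as the expected outcome. Compound 3 is estimated at 60000 nM with an expected range from 25000 nM to 120000 nM in this assay (estimate only).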

Compound 3, half-maximal inhibitory concentration: 28000 nM
For compound 3 the middle estimate is 2.1-fold (0.33 log units) above the measured one; the measured number falls inside the stated range.
By their numbers in this assay, from the lowest: compound 3; then compounds 2 and 1 (each within the scatter of the next).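

In this assay phenyl in place of methyl on a saturated chain carbon bound to an amine nitrogen gives a 2.7-fold lower number from compound 2 to compound 3 (0.43 log units; beyond the scatter) and this modest change is the only step shown beyond the scatter. Among the compounds shown here, the earlier ethylamino change left its pair unseparated, so the chain on that nitrogen is the first place where a change registers. No measurement shown accounts for this step. As far as these compounds go, whether the step needs the phenyl ring remains open. A cyclohexyl ring, a pyridine ring or a longer alkyl chain at this place would test that.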